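Cyclopropyl for propargyl on the amide nitrogen: toxicity outlook

This account rests on a few compounds, and the source may have more. Where it says the series, first, only, none or still open, it means among the compounds named here.

In a toxicity assay on the whole organism (strain Icem-CET (SPF Caw)) for cytotoxicity, with Mus musculus as the target (a lower number here means that less compound is needed, a higher number that more compound is needed for the effect), compound 1 `C/C(C(=O)NC1CC1)=C(\C)c1ccc(C)cc1` gives 280 mg/kg, compound 2 `C/C(C(=O)NC1CC1)=C(/C)c1ccc(Br)cc1` gives 100 mg/kg, and compound 3 `C#CCNC(=O)/C(C)=C(\C)c1ccc(C)cc1` gives 120 mg/kg. Compound 3 stands second highest of the three numbers; its value and that of compound 2 lie within the scatter of each other, while the value of compound 1 lies beyond it. Compound 4 `C/C(C(=O)NC1CC1)=C(/C)c1ccc(C)cc1` differs from compound 3 by cyclopropyl in place of propargyl on an amide-type nitrogen. Among the compounds with values here, no measured pair shows this change alone, so compound 4 is expected to move little in this assay, with a step of a 1.4-fold higher number from compound 3 to compound 4 (0.15 log units; within the scatter) that may not exceed the scatter. Compound 4 is therefore estimated at 170 mg/kg, with a range from 90 mg/kg to 320 mg/kg.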

Compound 4, dose for half-maximal effect: 110 mg/kg
Compound 4: middle estimate off by 1.5-fold (0.19 log units), on the high side, within the range that was stated.
By their numbers in this assay, from the lowest: compounds 2, 4 and 3 (each within the scatter of the next); then compound 1.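

In this assay cyclopropyl in place of propargyl on an amide-type nitrogen gives a 1.1-fold lower number from compound 3 to compound 4 (0.04 log units; within the scatter) and so does not separate the two groups at this position. Methyl in place of bromo on an aromatic carbon likewise stays within the scatter, with a 1.1-fold higher number from compound 2 to compound 4 (0.04 log units; within the scatter) as its step. Within the data shown here, the only step here beyond the scatter is a 2.5-fold lower number from compound 1 to compound 4 (0.41 log units; beyond the scatter) and it involves no change of group: the fact that compounds 1 and 4 differ only in the configuration as drawn.

On these data alone, whether the double-bond configuration counts as much with bromo on the aromatic carbon remains open. So does the effect of a longer chain or a carboxylic acid on the amide-type nitrogen.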